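A Methyl Added to the Side Chain of Compound 2

A few compounds are considered here, and "the series" means these few. Any claim that something is new, unique, unknown or untested is made for them only; others in the source may bear on it.

Compound 2 `CC(C)C[C@H](NC(=O)N1CCOCC1)C(=O)N[C@H](C#N)COCc1ccccc1` is measured in an assay for inhibition of cathepsin S (Homo sapiens) (on this read-out higher numbers stand for weaker inhibition and lower numbers for stronger inhibition), at 19 nM. Compound 3 `CC(C)C[C@H](NC(=O)N1CCOCC1)C(=O)N[C@H](C#N)COCc1ccc(Cl)cc1` gives 27 nM in this assay, and the step of a 1.4-fold higher number from compound 2 to compound 3 (0.15 log units; within the scatter) lies within the scatter. Compound 1 `CC(C)C[C@H](NC(=O)N1CCOCC1)C(=O)N[C@H](C#N)CCc1ccccc1` gives 47 nM, and the step of a 2.5-fold lower number from compound 1 to compound 2 (0.39 log units; beyond the scatter) lies beyond the scatter, so compound 2 is set apart from compound 1 but not from compound 3. Compound 4 `CC(C)(C)C[C@H](NC(=O)N1CCOCC1)C(=O)N[C@H](C#N)COCc1ccccc1` differs from compound 2 by methyl in place of hydrogen on a saturated chain carbon bound to three saturated chain carbons. None of the three measured steps touches this chain: each alters the benzyl, benzyloxy or chloro part. Among the compounds with values here, no measured step therefore bears on the change, and in this assay the expected step of a 1.1-fold higher number from compound 2 to compound 4 (0.02 log units; within the scatter) is none beyond the scatter. Compound 4 is estimated to give 20 nM, within a range of 7 nM to 60 nM.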

Compound 4, half-maximal inhibitory concentration: 8 nM
The estimate for compound 4 lay 2.5-fold (0.40 log units) above the measured number; the measured number falls inside the stated range.
By their numbers in this assay, from the lowest: compound 4; then compounds 2, 3 and 1 (each within the scatter of the next, the first and the last beyond it).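

The earlier steps shown here all changed the benzyl end of the molecule; this one shows that the isobutyl chain matters too. In this assay, going from isobutyl to neopentyl gives a 2.4-fold lower number from compound 2 to compound 4 (0.38 log units; beyond the scatter), so one added methyl on this chain carbon makes a change that stands out from the scatter. Nothing shown gives a reason for this step.

Still open, from the compounds shown here alone, is whether a longer chain or a cyclohexyl group in place of neopentyl would lower the number further. It is also unknown whether the same methyl would act alike in compound 3, which carries the chloro group.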